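A 3-carbamoylphenyl swap near a clearance limit

The source may hold more compounds than are shown below. What is called first, only, known or untested is meant among the compounds shown, and "the series" means these compounds.

Measured in an ADME assay (liver) for metabolic stability, with Liver microsome (Homo sapiens) as the target, using microsomes and NADPH, with a stated time of 30 min, tested at 1 uM; a higher number here means faster removal of the compound, a lower number slower removal:
Compound 1 `Nc1ccc(S(=O)(=O)N2CCN(c3ncc(C(O)(C(F)(F)F)C(F)(F)F)cc3C#CCO)CC2)cn1`: < 14 mL.min-1.g-1 (a limit)
Compound 2 `COCC#Cc1cc(C(O)(C(F)(F)F)C(F)(F)F)cnc1N1CCN(S(=O)(=O)c2ccc(N)nc2)CC1`: 15 mL.min-1.g-1
Compound 3 `Nc1ccc(S(=O)(=O)N2CCN(c3ncc(C(O)(C(F)(F)F)C(F)(F)F)cc3-c3ccoc3)CC2)cn1`: < 14 mL.min-1.g-1 (a limit)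

Compound 3 stands at the limit of < 14 mL.min-1.g-1 in this assay, at which 2 of the 3 values shown sit, so its result is a limit and not a number. Compound 4 `NC(=O)c1cccc(-c2cc(C(O)(C(F)(F)F)C(F)(F)F)cnc2N2CCN(S(=O)(=O)c3ccc(N)nc3)CC2)c1` carries 3-carbamoylphenyl in place of furan-3-yl on an aromatic carbon. The group sits ortho to a large group, and it has not been measured on this core.

Two measured steps change the same aromatic carbon: a step that the two limits leave unreadable from compound 1 to compound 3, and an at least 1.0-fold lower number from compound 2 to compound 3 (0.02 log units; that floor lies within the scatter). The first cannot be read, and the second has a floor within the scatter. A third step, an at least 1.0-fold higher number from compound 1 to compound 2 (0.02 log units; that floor lies within the scatter), changes only the end of the chain, with methyl in place of hydrogen on an oxygen on a saturated carbon. None of the three gives a direction for the new group, so no step beyond the scatter is expected in this assay. Within the data shown here, the expectation stays close to compound 2, which gives 15 mL.min-1.g-1, the only true number.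

The expected change is a number no lower from compound 3 to compound 4 (the limit leaves the size open). For compound 4 the estimate is 14 mL.min-1.g-1, with an expected range from 9 mL.min-1.g-1 to 28 mL.min-1.g-1.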

Compound 4, intrinsic clearance in microsomes: 17 mL.min-1.g-1
Beside the measured number, compound 4's estimate is 1.2-fold (0.08 log units) below it, and the stated range covers the measured number.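

In this assay, among these compounds, the only step at this aromatic carbon, ortho to a large group, that joins two true numbers is a 1.1-fold higher number from compound 2 to compound 4 (0.05 log units; within the scatter), so 3-carbamoylphenyl and 3-methoxyprop-1-yn-1-yl cannot be told apart here. The steps that start from limits read an at least 1.2-fold higher number from compound 3 to compound 4 (0.08 log units; that floor lies within the scatter) and an at least 1.2-fold higher number from compound 1 to compound 4 (0.08 log units; that floor lies within the scatter), and neither floor shows a real difference from furan-3-yl or 3-hydroxyprop-1-yn-1-yl. Compound 1 and compound 3 give limits and not numbers: the limit of < 14 mL.min-1.g-1 in this assay, at which 2 of the 4 values shown sit.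

From the compounds shown here alone, whether a carboxylic acid in place of the carbamoyl on the phenyl ring, or a longer chain in place of 3-methoxyprop-1-yn-1-yl, would give a step beyond the scatter stays open. Going by these compounds, how far compound 1 and compound 3 truly lie from compound 4 also stays open, as their limits fix only a floor for those steps.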